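The source may report more compounds than this note shows. Statements on the series, on what has been measured and on what is new or still open speak of the compounds shown alone.

Measured so far in a functional assay on Huh-7 cells (Homo sapiens) for inhibition, read by MTT assay, with a stated time of 48 h; on this read-out lower numbers stand for stronger inhibition and higher numbers for weaker inhibition:
compound 1 `O=C(/C=C/c1coc2cc(O)ccc2c1=O)NCc1ccccc1`, 4690 nM
compound 2 `COc1ccc2c(=O)c(/C=C/C(=O)NCc3ccccc3)coc2c1`, 13600 nM
compound 3 `COc1ccc(NC(=O)/C=C/c2coc3cc(OC)ccc3c2=O)cc1`, a limit only

Compound 3 gives in this assay only a limit, > 100000 nM, which is a bound of the assay and not a number; it sits at the limit of > 100000 nM in this assay, at which 1 of the 3 values shown sits.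

Two single changes are measured. From compound 2 to compound 1 the change is hydrogen in place of methyl on an oxygen on an aromatic ring and it gives a 2.9-fold lower number from compound 2 to compound 1 (0.46 log units; beyond the scatter). From compound 2 to compound 3 the change is 4-methoxyphenyl in place of benzyl on an amide-type nitrogen and it gives an at least 7.3-fold higher number from compound 2 to compound 3 (0.86 log units; beyond the scatter); this is also how the core of compound 3 differs from the core of compound 2.

Compound 4 `COc1ccc(NC(=O)/C=C/c2coc3cc(O)ccc3c2=O)cc1` is not yet measured. It differs from compound 3 by hydrogen in place of methyl on an oxygen on an aromatic ring, the same change as from compound 2 to compound 1, at a place described in the same words. Against the core of compound 3 the step is expected to be an at least 1.6-fold lower number from compound 3 to compound 4 (0.22 log units; that floor lies within the scatter), resting on the size of the earlier step from compound 2 to compound 1 a 2.9-fold lower number from compound 2 to compound 1 (0.46 log units; beyond the scatter) and on compound 3 standing only at a limit > 100000 nM. Compound 4 is therefore estimated at 60000 nM, between 20000 nM and 200000 nM.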

Compound 4, half-maximal inhibitory concentration: > 100000 nM
Compound 4: no number, only a limit (the forecaster's own chance of this, stated with the estimate: 45%); at least 1.6-fold (0.22 log units) between middle value and limit.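

In this assay compound 4 gives > 100000 nM as a limit of the assay and not a number. With compound 3 also at a limit, the step for hydrogen in place of methyl cannot be read, so the series neither confirms nor refutes that the methoxy to hydroxy change carries from the core of compound 2 to the core of compound 3. The other change, 4-methoxyphenyl in place of benzyl on an amide-type nitrogen, reads as an at least 21-fold higher number from compound 1 to compound 4 (1.32 log units; beyond the scatter) and goes the same way on both cores, though its size cannot be compared between them: the same change on two cores in this assay, an at least 7.3-fold higher number (0.86 log units; beyond the scatter) from compound 2 to compound 3 and an at least 21-fold higher number (1.32 log units; beyond the scatter) from compound 1 to compound 4; the limit leaves it open whether they differ.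

Going by these compounds, it remains open whether hydrogen in place of methyl has any effect on a core with 4-methoxyphenyl on the amide-type nitrogen. Also open, on these data alone, is how an unsubstituted phenyl or a 2-phenylethyl chain on that nitrogen would stand against benzyl.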